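Swapping a Flexible Amine for a Bridged Bicyclic One

This account rests on a few compounds, and the source may have more. Where it says the series, first, only, none or still open, it means among the compounds named here.

Of the compounds shown here, two have been measured in an assay on isolated protein for displacement of a labelled ligand from melanin-concentrating hormone receptor 1 (Homo sapiens); on this read-out higher numbers stand for weaker inhibition and lower numbers for stronger inhibition. Compound 1 `CCCN(CCC)c1ccc2cc(NC(=O)CCc3ccc(C(F)(F)F)cc3)ccc2n1` gives 490 nM. Compound 2 `O=C(CCCCCCCCCCCCc1ccc(C(F)(F)F)cc1)Nc1ccc2nc([N+]34CCC(CC3)CC4)ccc2c1` gives 5 nM in this assay. Compound 1 thus stands at the highest number of the two, and its gap to compound 2 lies beyond the usual scatter. Compound 2 differs from compound 1 in more than one place, so no single structural step can be read from that pair; only the two values themselves can be compared.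

Compound 3 `O=C(CCc1ccc(C(F)(F)F)cc1)Nc1ccc2nc(N3CC4CCC3CC4)ccc2c1` has not yet been measured. It differs from compound 1 in one place: a group of 8 heavy atoms (7 carbon, 1 nitrogen; 2 six-membered non-aromatic rings with 1 hetero atom each) in place of a group of 7 heavy atoms (6 carbon, 1 nitrogen; no ring), on an aromatic carbon. The dipropylamino group leaves, and two six-membered non-aromatic rings with one hetero atom each enter on the aromatic carbon next to the ring nitrogen.

Among the measured compounds shown here, no measured pair shows this change alone, so the expectation rests on the two values only, and compound 2 offers weak guidance since it differs in several places. Compound 3 is estimated at 120 nM, within 30 nM to 450 nM. The expected step of a 4.1-fold lower number from compound 1 to compound 3 (0.61 log units; beyond the scatter) is a moderate lowering, beyond the scatter.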

Compound 3, half-maximal inhibitory concentration: 3 nM
For compound 3 the middle estimate is 40-fold (1.60 log units) above the measured one; measured number below the stated range.
By their numbers in this assay, from the lowest: compounds 3 and 2 (each within the scatter of the next); then compound 1.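

In this assay, exchanging the dipropylamino group for the bridged bicyclic amine gives a 160-fold lower number from compound 1 to compound 3 (2.21 log units; beyond the scatter), and this is a large step from a single change on the aromatic carbon next to the ring nitrogen. Among the compounds shown here, this is the first pair that isolates this position, and it shows that the group there can by itself move the number strongly while the rest of the molecule stays the same. The counts barely differ, with 8 heavy atoms in place of 7, matching hydrogen-bond donor and acceptor counts and no net charge on either group, and no measurement shown here bears on the cause of the step.

From the compounds shown here alone, it remains open whether a single ring, such as piperidine or pyrrolidine, would give a similar number at this carbon, or whether a smaller open-chain amine, such as dimethylamino, would behave more like the dipropylamino group. Also open, going by these compounds, is whether the exchange would give a step of similar size if the trifluoromethyl group were replaced by chlorine or a nitrile.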